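Replacing the Amide Substituent on the Shared Core

A few compounds are considered here, and "the series" means these few. Any claim that something is new, unique, unknown or untested is made for them only; others in the source may bear on it.

Compound 1, `O=C(O)C1CCN(c2ccc(C(F)(F)F)cc2)C1`: 50000 nM
Compound 2, `COCCNC(=O)C1CCN(c2ccc(Cl)c(C(F)(F)F)c2)C1`: 3500 nM

In an assay on cells for inhibition of Palmitoleoyl-protein carboxylesterase NOTUM variant C330S (Homo sapiens), read by fluorescence, with a stated time of 40 min (a lower number here means a stronger inhibitor, a higher number a weaker inhibitor), compound 2 gives 3500 nM, the lower of the two numbers, while compound 1 gives 50000 nM, a gap beyond the usual scatter, so compound 2 is the stronger inhibitor of the pair. Compound 3, `CN1CCN(C(=O)C2CCN(c3ccc(Cl)c(C(F)(F)F)c3)C2)CC1=O`, differs from compound 2 in one place: 4-methyl-3-oxopiperazin-1-yl in place of (2-methoxyethyl)amino on a carbonyl carbon. For the measured compounds named here, no measured pair shows this change, so in this assay the step of a 1.2-fold lower number from compound 2 to compound 3 (0.07 log units; within the scatter) is expected to be small, within the scatter, with no clear direction. Compound 3 is therefore estimated at 3000 nM, within a range from 800 nM to 12000 nM.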

Compound 3, half-maximal inhibitory concentration: 3100 nM
Compound 3: the middle estimate sits 1.0-fold (0.01 log units) below what was measured; measured number inside the range.
By their numbers in this assay, from the lowest: compounds 3 and 2 (each within the scatter of the next); then compound 1.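

In this assay, the position on the carbonyl carbon now has its first direct comparison (a 1.1-fold lower number from compound 2 to compound 3 (0.05 log units; within the scatter)). The open (2-methoxyethyl)amino chain and the ring of 4-methyl-3-oxopiperazin-1-yl therefore give values within the scatter of each other, even though the new group has a six-membered ring and lacks the amide hydrogen. Nothing measured here accounts for this result. The compounds shown leave open how a piperazine with a free ring amine or a longer ether chain would read at this position.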